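Small aryl swap on a weakly cytotoxic scaffold

The source may hold more compounds than are shown below. What is called first, only, known or untested is meant among the compounds shown, and "the series" means these compounds.

Compound 1 (`Cc1ccc(-c2cc3ccccc3c(O)n2)cc1`) gives 13800 nM
Compound 2 (`Cc1ccc2c(O)nc(-c3ccccc3C)cc2c1`) gives 4270 nM
Compound 3 (`COc1ccc(-c2cc3cc(C)ccc3c(N3CCN(C)CC3)n2)cc1`) gives 7940 nM

In a functional assay on SK-OV-3 cells (Homo sapiens) for cytotoxicity (on this read-out higher numbers stand for weaker inhibition and lower numbers for stronger inhibition), compound 3 lies within the usual scatter of both compound 1 and compound 2, so its number stands clearly apart from neither. Compound 4 (`Cc1ccc2c(N3CCN(C)CC3)nc(-c3ccccc3C)cc2c1`) keeps the 4-methylpiperazin-1-yl group of compound 3 but has 2-methylphenyl in place of 4-methoxyphenyl on an aromatic carbon. Within the data shown here, no measured pair isolates this swap. Compound 2 also carries 2-methylphenyl and gives 4270 nM in this assay, within the scatter of compound 3. The expected change a 1.4-fold lower number from compound 3 to compound 4 (0.16 log units; within the scatter) is therefore small, with no step beyond the scatter. For compound 4 the estimated value is 5500 nM, with an expected range of 2000 nM to 15000 nM overall.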

Compound 4, half-maximal inhibitory concentration: 5130 nM
Compound 4: middle estimate off by 1.1-fold (0.03 log units), on the high side, within the range that was stated.
By their numbers in this assay, from the lowest: compounds 2, 4, 3 and 1 (each within the scatter of the next, the first and the last beyond it).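

Swapping 4-methoxyphenyl for 2-methylphenyl at this position gives a 1.5-fold lower number from compound 3 to compound 4 (0.19 log units; within the scatter) in this assay and stays inside the scatter, so neither aryl group stands apart here. Putting 4-methylpiperazin-1-yl in place of hydroxy gives a 1.2-fold higher number from compound 2 to compound 4 (0.08 log units; within the scatter) and likewise stays inside the scatter. Nothing available explains either result.

Both changes therefore leave the number essentially where it was. As far as these compounds go, whether a carboxylic acid in place of 2-methylphenyl, or a simple amine in place of 4-methylpiperazin-1-yl, would move the number beyond the scatter remains open.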